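This account rests on a few compounds, and the source may have more. Where it says the series, first, only, none or still open, it means among the compounds named here.

Measured in a functional assay on HT-29 cells (Homo sapiens) for antiproliferative activity, read by sulforhodamine B assay, with a stated time of 48 h; a higher number here means a weaker inhibitor, a lower number a stronger inhibitor:
compound 1 (`Cc1ccccc1OS(=O)(=O)c1ccc(N2CCN(C)C2=O)cc1`) 4800 nM
compound 2 (`CCc1ccccc1OS(=O)(=O)c1ccc(N2CCN(C)C2=O)cc1`) 4600 nM
compound 3 (`CN1CCN(c2ccc(S(=O)(=O)Oc3cc(Cl)c(Cl)cc3Cl)cc2)C1=O`) 600 nM

Compound 1 sits at the high end of these numbers, within the scatter of compound 2, and compound 3 reads clearly lower than both. Compound 4 (`Cc1cccc(OS(=O)(=O)c2ccc(N3CCN(C)C3=O)cc2)c1`) has the same atoms as compound 1, joined differently (3-methylphenyl in place of 2-methylphenyl on an oxygen). It carries 3-methylphenyl in place of 2-methylphenyl on an oxygen whose other neighbour is the sulfonyl sulfur.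

Going by the values given here, the only measured step is a 1.0-fold lower number from compound 1 to compound 2 (0.02 log units; within the scatter) and it adds a methyl in place of hydrogen on a saturated chain carbon, so it bears on this change only indirectly. No measurement shows what moving the methyl does. Compound 3 differs too much from compound 1 to serve as a guide. With so little evidence, no change beyond the scatter is expected in this assay and the range is kept wide. The expected step is a 1.1-fold lower number from compound 1 to compound 4 (0.06 log units; within the scatter) (an estimate). For compound 4 the estimated value is 4200 nM (expected range 1600 nM to 10000 nM).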

Compound 4, half-maximal inhibitory concentration: 4300 nM
Beside the measured number, compound 4's estimate is 1.0-fold (0.01 log units) below it, within the range that was stated.
By their numbers in this assay, from the lowest: compound 3; then compounds 4, 2 and 1 (each within the scatter of the next).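

In this assay, going by these compounds alone, putting 3-methylphenyl in place of 2-methylphenyl on the oxygen whose other neighbour is the sulfonyl sulfur gives a 1.1-fold lower number from compound 1 to compound 4 (0.05 log units; within the scatter), which is the first direct reading of a shift of the methyl at this place. Compound 4 also stands close to the 2-ethylphenyl compound, with a 1.1-fold lower number from compound 2 to compound 4 (0.03 log units; within the scatter), so neither this shift of the methyl nor the change from 2-ethylphenyl to 3-methylphenyl moves the number beyond the scatter. Nothing available accounts for this closeness.

The compounds shown leave open whether a methoxy group, an amine or a carboxylic acid on this aromatic ring would read differently from the methyl and ethyl compounds. They also leave open whether a single chlorine would be enough to move the number beyond the scatter.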